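Stability of a Butyryl Ester in Buffer

A few compounds are considered here, and "the series" means these few. Any claim that something is new, unique, unknown or untested is made for them only; others in the source may bear on it.

Going by the values given here, compound 1 `Nc1nc(F)c2ncn(COC(CO)CO)c2n1` holds the higher of the two numbers known so far. In an ADME assay for pharmacokinetics, in phosphate buffer, at pH 7.4 (a higher number here means that the compound lasts longer, a lower number that the compound disappears faster), compound 1 gives 1660 h. Compound 2 `CC(=O)OCC(CO)OCn1cnc2c(F)nc(N)nc21` carries an acetyl group on one hydroxyl; in this assay compound 2 gives 336 h, and the step of a 4.9-fold lower number from compound 1 to compound 2 (0.69 log units; beyond the scatter). Compound 3 `CCCC(=O)OCC(CO)OCn1cnc2c(F)nc(N)nc21` differs from compound 1 by propylcarbonyl in place of hydrogen on an oxygen on a saturated carbon. Among the compounds with values here, the acetyl step is the only measured change that bears on this, and another ester is entered, so a drop of roughly that size is expected, a 5.9-fold lower number from compound 1 to compound 3 (0.77 log units; beyond the scatter). Compound 3 is therefore estimated at 280 h, within 90 h to 900 h.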

Compound 3, half-life: 504 h
The estimate for compound 3 lay 1.8-fold (0.26 log units) below the measured number; measured number inside the range.
By their numbers in this assay, from the lowest: compounds 2 and 3 (each within the scatter of the next); then compound 1.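

In this assay, a second ester on this oxygen also lowers the half-life (a 3.3-fold lower number from compound 1 to compound 3 (0.52 log units; beyond the scatter)), so the drop is not confined to the acetyl group. Ethyl in place of hydrogen on a saturated chain carbon bound to a carbonyl carbon leaves the two esters within the scatter of each other (a 1.5-fold higher number from compound 2 to compound 3 (0.18 log units; within the scatter)). Nothing at hand explains the behaviour of either ester. Going by these compounds, whether a longer chain would stay level with compounds 2 and 3 remains open. So does the effect of an amine on the ester chain.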